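Working notes: aryl exchange on the ring nitrogen

The compounds below may be only part of what the source reports. "The series", "measured", "known", "first", "only" and "open" are said of these compounds alone.

Two compounds of this series carry numbers in a functional assay on PC-3 cells (Homo sapiens) for cytotoxicity, read by MTT assay, with a stated time of 72 h; a higher number here means a weaker inhibitor, a lower number a stronger inhibitor. Compound 1 `COc1ccc(-n2ccc(=O)c(C(=O)Nc3ccc(Oc4ccnc5[nH]ccc45)c(F)c3)n2)cc1` gives 46400 nM. Compound 2 `O=C(Nc1ccc(Oc2ccnc3[nH]ccc23)c(F)c1)c1nn(-c2ccccc2)ccc1=O`, bearing hydrogen in place of methoxy on an aromatic carbon, gives 38600 nM. Among the compounds with values here, the single measured step, a 1.2-fold lower number from compound 1 to compound 2 (0.08 log units; within the scatter), lies within the scatter, so compound 2 stands at the lower of the two numbers only nominally, with compound 1 a near neighbour rather than a separated point.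

Compound 3 `O=C(Nc1ccc(Oc2ccnc3[nH]ccc23)c(F)c1)c1nn(-c2ccc(Cl)c(C(F)(F)F)c2)ccc1=O` has not been measured. It differs from compound 2 by 4-chloro-3-(trifluoromethyl)phenyl in place of phenyl on an aromatic nitrogen. Within the data shown here, the one step available bears on the same ring: a 1.2-fold lower number from compound 1 to compound 2 (0.08 log units; within the scatter) shows that altering a substituent on that phenyl left the number within the scatter. That is the whole evidence; the present change replaces the ring itself with a 4-chloro-3-(trifluoromethyl)phenyl, a larger alteration than anything measured, so the uncertainty is wide. On this basis no step beyond the scatter is expected for compound 3, estimated as a 1.3-fold lower number from compound 2 to compound 3 (0.11 log units; within the scatter). Compound 3 is expected at 30000 nM, with a range from 8000 nM to 120000 nM.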

Compound 3, half-maximal inhibitory concentration: 5500 nM
Compound 3: the middle estimate sits 5.5-fold (0.74 log units) above what was measured; the measured number lies below the stated range.
By their numbers in this assay, from the lowest: compound 3; then compounds 2 and 1 (each within the scatter of the next).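

Working notes, continued: the aryl group on the ring nitrogen is not a silent position in this assay, since 4-chloro-3-(trifluoromethyl)phenyl in place of phenyl gives the first step of the series beyond the scatter, a 7.0-fold lower number from compound 2 to compound 3 (0.85 log units; beyond the scatter), whereas the exchange of methoxy for hydrogen on that ring did not leave the scatter. The comparison with the 4-methoxyphenyl group points the same way, an 8.4-fold lower number from compound 1 to compound 3 (0.93 log units; beyond the scatter), so compound 3 stands apart from both earlier aryl variants, which themselves remain within the scatter of each other. Nothing at hand bears on why the number falls with this particular group.

Open, on these data alone, is whether the step belongs to the 4-chloro group, to the 3-trifluoromethyl group or only to the two together, a question that a phenyl carrying just one of them would settle. Equally open, as far as these compounds go, is how far this position tolerates quite different substituents on the same ring, such as an amine, a carboxylic acid or a longer alkyl chain, and whether the lower number would hold with any of them.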